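A few compounds are considered here, and "the series" means these few. Any claim that something is new, unique, unknown or untested is made for them only; others in the source may bear on it.

Compound 1 `CC(C(=O)NCc1ccc(Br)cc1)c1ccc(NS(C)(=O)=O)c(F)c1`: 412 nM in an assay on CHO cells for displacement of a labelled ligand from transient receptor potential cation channel subfamily V member 1 (Rattus norvegicus); a higher number here means a weaker inhibitor, a lower number a stronger inhibitor
Compound 2 `CC(C(=O)NCc1ccc(C(F)(F)F)cc1)c1ccc(NS(C)(=O)=O)c(F)c1`: 660 nM
Compound 3 `CC(C(=O)NCc1ccc(C(C)(C)C)cc1C#N)c1ccc(NS(C)(=O)=O)c(F)c1`: 44 nM

Among these three numbers compound 1 stands second highest, close to compound 2 and far from compound 3. Compound 4 `CC(C(=O)NCCCc1ccc(Cl)cc1)c1ccc(NS(C)(=O)=O)c(F)c1` differs from compound 1 in one place: 2-(4-chlorophenyl)ethyl in place of 4-bromophenyl on a saturated chain carbon bound to an amide-type nitrogen. Among the compounds with values here, the only measured single step, a 1.6-fold higher number from compound 1 to compound 2 (0.20 log units; within the scatter), exchanges the group on the aromatic ring while keeping the chain, and it stayed within the scatter. Within the data shown here, no measured pair changes the chain length itself, so that part of the change has no precedent here. For compound 4 the expected outcome in this assay is therefore a step of about a 1.5-fold higher number from compound 1 to compound 4 (0.16 log units; within the scatter), most likely within the scatter, with a wide range. The estimate for compound 4 is 600 nM, between 150 nM and 2500 nM.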

Compound 4, inhibition constant: 470 nM
The estimate for compound 4 lay 1.3-fold (0.11 log units) above the measured number; the range from low to high includes it.
By their numbers in this assay, from the lowest: compound 3; then compounds 1, 4 and 2 (each within the scatter of the next).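

In this assay, the exchange on a saturated chain carbon bound to an amide-type nitrogen gave a 1.1-fold higher number from compound 1 to compound 4 (0.06 log units; within the scatter), so the position accepted 2-(4-chlorophenyl)ethyl, with its 9 heavy atoms, in place of 4-bromophenyl, with its 7, and this step altered more than the group on the aromatic ring. Nothing available here explains this result. From the compounds shown here alone, because chain and halogen changed together, their separate contributions remain open. So does whether a longer chain, such as 3-(4-chlorophenyl)propyl, or an amine on the chain would stay within the same range.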